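Compound 3: a (3-nitrophenyl)carbamoyl group enters

A few compounds are considered here, and "the series" means these few. Any claim that something is new, unique, unknown or untested is made for them only; others in the source may bear on it.

In a functional assay on HL-60 cells (Homo sapiens) for inhibition, read by CCK-8 assay, with a stated time of 48 h (on this read-out lower numbers stand for stronger inhibition and higher numbers for weaker inhibition), compound 1 `COc1cccc(NC(=O)NCCNS(=O)(=O)c2ccc(-c3ccccc3OCc3ccccc3)s2)c1` gives 1700 nM. Compound 2 `O=[N+]([O-])c1cccc(NC(=S)NCCNS(=O)(=O)c2ccc(-c3ccccc3OCc3ccccc3)s2)c1` stands only at a limit of this assay, > 50000 nM. For the measured compounds named here, the one measured step, an at least 29-fold higher number from compound 1 to compound 2 (1.46 log units; beyond the scatter), is large and bears directly on what follows. Compound 3 `O=C(NCCNS(=O)(=O)c1ccc(-c2ccccc2OCc2ccccc2)s1)Nc1cccc([N+](=O)[O-])c1` differs from compound 2 by a group of 12 heavy atoms (7 carbon, 2 nitrogen, 3 oxygen; one six-membered aromatic ring of carbon only) in place of a group of 12 heavy atoms (7 carbon, 2 nitrogen, 2 oxygen, 1 sulfur; one six-membered aromatic ring of carbon only), on an amine nitrogen, which brings the group on the amine nitrogen closer in its counts to that of compound 1. Given an at least 29-fold higher number from compound 1 to compound 2 (1.46 log units; beyond the scatter), a large step to a lower number is expected, though not a full return. The expected change is an at least 12-fold lower number from compound 2 to compound 3 (1.09 log units; beyond the scatter). For compound 3 the estimate is 4000 nM, within a range of 900 nM to 25000 nM.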

Compound 3, half-maximal inhibitory concentration: 2800 nM
The estimate for compound 3 lay 1.4-fold (0.15 log units) above the measured number, and the stated range covers the measured number.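

The (3-nitrophenyl)carbamoyl group on the amine nitrogen gives an at least 17-fold lower number from compound 2 to compound 3 (1.25 log units; beyond the scatter), so the weak result of compound 2 goes with the sulfur-bearing group and not with the nitro group alone. That step starts from a limit of the assay, not from a number, for compound 2: the limit of > 50000 nM in this assay, at which 1 of the 3 values shown sits. In this assay, nitro in place of methoxy on an aromatic carbon gives a 1.6-fold higher number from compound 1 to compound 3 (0.22 log units; within the scatter), which shows no change. As far as these compounds go, whether sulfur in place of the carbonyl oxygen has the same result with methoxy on the aromatic ring remains open. So does how an amine or a carboxylic acid on that aromatic carbon would read.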